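The source may report more compounds than this note shows. Statements on the series, on what has been measured and on what is new or still open speak of the compounds shown alone.

Measured compounds and their values in a functional assay on L1210 cells (Mus musculus) for antiproliferative activity; a lower number here means that less compound is needed, a higher number that more compound is needed for the effect:

Compound 1, `CCCCCCCO/N=C/c1cc(OC)c2c(c1OC)C(=O)C=CC2=O`: 0.213 ug/mL
Compound 2, `CCCCCO/N=C/c1cc(OC)c2c(c1OC)C(=O)C=CC2=O`: 0.175 ug/mL
Compound 3, `CCCCCC/C(=N\OC)c1cc(OC)c2c(c1OC)C(=O)C=CC2=O`: 0.192 ug/mL

The three compounds share one core and differ only in the chain attached through the oxygen and in the group on the carbon of the oxime. Compound 3 stands second highest of the three numbers, nearest to compound 2 and furthest from compound 1, with all three values within the scatter of one another, so no order among them can be claimed.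

Compound 4, `CCCCCCCCCO/N=C(\CCCCCC)c1cc(OC)c2c(c1OC)C(=O)C=CC2=O`, has not yet been measured. It differs from compound 3 by octyl in place of hydrogen on a saturated chain carbon bound to an oxygen on an unsaturated carbon; cut one bond further out, the same change reads methyl to nonyl, or methoxy to nonyloxy.

Within the data shown here, the one measured step that bears on a change of chain length is the step of a 1.2-fold lower number from compound 1 to compound 2 (0.09 log units; within the scatter), where a shorter chain on the oxygen gave a number within the scatter. Among the measured compounds shown here, no measured pair covers a chain as long as octyl, so the expectation rests on this single step. Compound 4 is therefore expected to give a step of a 1.1-fold higher number from compound 3 to compound 4 (0.06 log units; within the scatter) that stays within the scatter, with an estimated value of 0.22 ug/mL, from 0.1 ug/mL to 0.5 ug/mL.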

Compound 4, concentration for half-maximal effect: 1.15 ug/mL
Compound 4: the middle estimate sits 5.2-fold (0.72 log units) below what was measured; the whole stated range lies below it.
By their numbers in this assay, from the lowest: compounds 2, 3 and 1 (each within the scatter of the next); then compound 4.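

In this assay, among these compounds, the change from methyl to nonyl on the oxime oxygen gives a 6.0-fold higher number from compound 3 to compound 4 (0.78 log units; beyond the scatter) and so produces the first step in this set that lies beyond the scatter. The only earlier step that shortens or lengthens a chain on that oxygen, a 1.2-fold lower number from compound 1 to compound 2 (0.09 log units; within the scatter) in a series with hydrogen on the oxime carbon, had shown no response to chain length, whereas this result shows that the position is not indifferent to the chain it carries once that chain reaches nonyl, at least when the oxime carbon bears the chain already present in compound 3. No measurement among those given accounts for this rise, so the data describe the size of the step but offer no explanation for it.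

The compounds shown leave open whether the number climbs gradually with each added carbon between methyl and nonyl or rises abruptly near the end of that range, and whether nonyl would have the same effect with hydrogen on the oxime carbon. They also leave open whether a long chain ending in an amine or a carboxylic acid would behave as nonyl does.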